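Polyacetylenic hydroxy acids: cytotoxicity on LNCaP cells

A few compounds are considered here, and "the series" means these few. Any claim that something is new, unique, unknown or untested is made for them only; others in the source may bear on it.

Measured so far:
compound 1, `O=C(O)CCCCCCCC#CC#CC#CC#C[C@@H](O)CO`: 9.2 ug/mL
compound 2, `C[C@H](O)C#CC#CC#CC#CCCCCCCCC(=O)O`: 1.6 ug/mL

For the measured compounds named here, in a functional assay on LNCaP cells (Homo sapiens) for cytotoxicity (on this read-out higher numbers stand for an effect only at larger amounts of compound and lower numbers for an effect already at smaller amounts), compound 2 has the lowest of the two numbers; the nearest is compound 1, and the single step between the two is a 5.8-fold lower number from compound 1 to compound 2 (0.76 log units; beyond the scatter). That single step exchanges hydrogen in place of hydroxy on a saturated chain carbon, two bonds along the chain from an oxygen on a saturated carbon and a triple-bonded carbon.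

Compound 3, `C[C@H](O)/C=C/C#CC#CC#CCCCCCCCC(=O)O`, is not yet measured in this assay. It differs from compound 2 by 3-hydroxybut-1-en-1-yl in place of 3-hydroxybut-1-yn-1-yl on a triple-bonded carbon. Going by the values given here, no measured step touches the unsaturation pattern of the chain: the step from compound 1 to compound 2 alters only the terminal oxygen and gives no guide to turning a triple bond into a double bond. Among the compounds with values here, with no bearing step at hand, the expected step in this assay is a 1.6-fold higher number from compound 2 to compound 3 (0.19 log units; within the scatter), that is, none beyond the scatter, with wide uncertainty in either direction. The value for compound 3 in this assay is estimated at 2.5 ug/mL, with a range from 1 ug/mL to 7 ug/mL.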

Compound 3, concentration for half-maximal effect: 0.3 ug/mL
The estimate for compound 3 lay 8.3-fold (0.92 log units) above the measured number; the measured number lies below the stated range.
By their numbers in this assay, from the lowest: compound 3; then compound 2; then compound 1.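

In this assay the exchange of 3-hydroxybut-1-yn-1-yl for 3-hydroxybut-1-en-1-yl on a triple-bonded carbon gives a 5.3-fold lower number from compound 2 to compound 3 (0.73 log units; beyond the scatter) and so shows what the earlier step, a change of hydroxy only, could not: a change from triple to double bond alone moves the number beyond the scatter, while the counts of heavy atoms, hydrogen-bond donors and acceptors and defined stereocentres stay the same. Read against the most hydroxylated end group, 3-hydroxybut-1-en-1-yl in place of 3,4-dihydroxybut-1-yn-1-yl gives a 31-fold lower number from compound 1 to compound 3 (1.49 log units; beyond the scatter) and is the only step of the three marked as large. Nothing at hand bears on why the double bond goes with the lower number.

As far as these compounds go, whether the shift belongs to this triple bond alone or would follow a double bond placed elsewhere along the chain stays open. Also open, from the compounds shown here alone, is how the end group reads with an amine in place of its hydroxy, or with a methyl ester in place of the carboxylic acid at the far end of the chain.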